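A few compounds are considered here, and "the series" means these few. Any claim that something is new, unique, unknown or untested is made for them only; others in the source may bear on it.

In a functional assay on HepG2 cells (Homo sapiens) for inhibition, read by MTT assay (a higher number here means a weaker inhibitor, a lower number a stronger inhibitor), three amides sharing one core have been measured: compound 1 `COc1cc2ncnc(Nc3ccc(NC(=O)c4ccccc4C)cc3)c2cc1OC` gives 15000 nM, compound 2 `COc1cc2ncnc(Nc3ccc(NC(=O)c4cccc(C)c4)cc3)c2cc1OC` gives 7500 nM, and compound 3 `COc1cc2ncnc(Nc3ccc(NC(=O)c4ccccc4F)cc3)c2cc1OC` gives 13000 nM. All three numbers lie within the usual scatter of one another, so compound 3 cannot be separated from either neighbour, and the series offers no firm ranking yet.

The next compound, compound 4 `COc1cc2ncnc(Nc3ccc(NC(=O)c4ccc(F)cc4)cc3)c2cc1OC`, keeps the same atoms but joins them differently, with 4-fluorophenyl in place of 2-fluorophenyl on a carbonyl carbon.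

For the measured compounds named here, no measured step shows this exact change. Going by the values given here, the nearest precedent also relocates a group on that ring, this time a methyl group, and it gives a 2.0-fold lower number from compound 1 to compound 2 (0.30 log units; within the scatter). Exchanging methyl for fluoro gives a 1.2-fold lower number from compound 1 to compound 3 (0.06 log units; within the scatter), while the remaining comparison gives a 1.7-fold higher number from compound 2 to compound 3 (0.24 log units; within the scatter). None of these steps rises beyond the scatter, so the series gives no reason to predict a large effect from moving the fluoro group.

The expected result is a 1.3-fold lower number from compound 3 to compound 4 (0.11 log units; within the scatter), which means no expected change beyond the scatter. For compound 4, the estimated value is 10000 nM, with an expected range from 5000 nM to 20000 nM.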

Compound 4, half-maximal inhibitory concentration: 15000 nM
Estimate against measurement, compound 4: 1.5-fold (0.18 log units) below; the range from low to high includes it.
By their numbers in this assay, from the lowest: compounds 2, 3, 1 and 4 (each within the scatter of the next).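

In this assay, relocating the fluoro group from 2-fluorophenyl to 4-fluorophenyl on the carbonyl carbon gives a 1.2-fold higher number from compound 3 to compound 4 (0.06 log units; within the scatter) and is the only direct reading of this move among the compounds shown; like the relocated methyl group, it stays inside the scatter. For the compounds shown here, the 4-fluorophenyl amide also cannot be separated from either methyl compound, with a 2.0-fold higher number from compound 2 to compound 4 (0.30 log units; within the scatter) and no change at the digits printed from compound 1 to compound 4 (within the scatter), so across these four substituted phenyl groups, no step at this position rises beyond the scatter and the compounds still have no firm ranking. No supporting measurement is available to explain this result.

The compounds shown carry only a methyl or a fluoro group on this ring, so they leave open whether an amine, a carboxylic acid or a longer chain such as butyl in that place would move the number beyond the scatter. As far as these compounds go, the 3-fluorophenyl and 4-methylphenyl amides would complete the comparison of positions for these two groups, and the effect of changing the shared core also remains open.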